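The source may report more compounds than this note shows. Statements on the series, on what has been measured and on what is new or still open speak of the compounds shown alone.

For the measured compounds named here, compound 1 `O=c1c(Cl)c(CSC(=S)N2CCOCC2)oc2ccccc12` is the only compound here with an actual number in a functional assay on MCF7 cells (Homo sapiens) for antiproliferative activity, read by MTT assay, with a stated time of 72 h (a higher number here means a weaker inhibitor, a lower number a stronger inhibitor), where compound 1 gives 11100 nM. Compound 2 `COc1ccc2occ(CSC(=S)N3CCCCC3)c(=O)c2c1` reaches only a limit of this assay, > 40000 nM. Compound 3 `COc1ccc2occ(CSC(=S)N(C(C)C)C(C)C)c(=O)c2c1` likewise reaches only a limit, > 40000 nM. Going by the values given here, the one measured step, a step that the two limits leave unreadable from compound 2 to compound 3, therefore cannot be read, as the limit of > 40000 nM in this assay, at which 2 of the 3 values shown sit, shows. Compound 4 `O=c1c(Cl)c(CSC(=S)N2CCCCC2)oc2ccccc12` differs from compound 1 as follows: piperidin-1-yl in place of morpholin-4-yl on a thiocarbonyl carbon. Among the compounds with values here, no measured step touches this exchange on the shared core of compound 1, and the pair of compound 2 and compound 3 gives no usable size. With no evidence for a shift in either direction, a step within the scatter is expected, a 1.1-fold higher number from compound 1 to compound 4 (0.03 log units; within the scatter). Compound 4 is thus estimated at 12000 nM, with a range from 4000 nM to 40000 nM.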

Compound 4, half-maximal inhibitory concentration: 1000 nM
Beside the measured number, compound 4's estimate is 12-fold (1.08 log units) above it; measured number outside the range, below it.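

On the shared core of compound 1, the group on the thiocarbonyl carbon clearly matters in this assay: replacing morpholin-4-yl with piperidin-1-yl gives an 11-fold lower number from compound 1 to compound 4 (1.05 log units; beyond the scatter). The two rings have the same size and differ in that morpholin-4-yl holds an oxygen, so a single ring atom goes with a step beyond the scatter. The earlier compounds gave no readable size for any exchange at this place, and the step between compound 2 and compound 3 still cannot be read: the limit of > 40000 nM in this assay, at which 2 of the 4 values shown sit.

Open, as far as these compounds go, is whether a smaller ring such as pyrrolidin-1-yl, or a ring with a second nitrogen such as piperazin-1-yl, would give a lower or higher number on this core.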